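Series notes: halogen to methyl on the shared core

The compounds below may be only part of what the source reports. "The series", "measured", "known", "first", "only" and "open" are said of these compounds alone.

Measured so far:
compound 1 `O=C(CCCc1ccccc1)Nc1nc2ccc(Cl)cc2c(=O)s1` — > 1000 nM
compound 2 `O=C(CCCc1ccccc1)Nc1nc2ccc(Br)cc2c(=O)s1` — > 1000 nM

In an assay on CHO cells for displacement of a labelled ligand from adenosine receptor A3 (Homo sapiens), read by scintillation counting, with a stated time of 60 min (a higher number here means a weaker inhibitor, a lower number a stronger inhibitor), compound 1 gives > 1000 nM, which is a limit of the assay and not a number. In this assay compound 2 gives > 1000 nM, again a limit and not a number. Compound 2 therefore stands at the limit, with no measured number to place it against. The step that the two limits leave unreadable from compound 1 to compound 2 cannot be read, because the limit of > 1000 nM in this assay, at which 2 of the 2 values shown sit, holds both values shown.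

Compound 3 `Cc1ccc2nc(NC(=O)CCCc3ccccc3)sc(=O)c2c1` is the next member. The change from compound 2 is methyl in place of bromo on an aromatic carbon. Within the data shown here, no measured step gives a size for a halogen to methyl exchange on the shared core; the only measured step is unreadable. Both neighbours sit at the limit, so compound 3 is expected to sit at or near it as well, with the step that the limit leaves unreadable from compound 2 to compound 3 estimated as small. The estimate for compound 3 in this assay is 3000 nM, expected between 700 nM and 20000 nM.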

Compound 3, inhibition constant: 147 nM
Beside the measured number, compound 3's estimate is 20-fold (1.31 log units) above it; measured number outside the range, below it.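

In this assay, this position on the six-membered aromatic ring of carbon only proves sensitive to the group it carries, which the two halogens alone could not show. Methyl gives an at least 6.8-fold lower number from compound 2 to compound 3 (0.83 log units; beyond the scatter), and against the chloro compound it gives an at least 6.8-fold lower number from compound 1 to compound 3 (0.83 log units; beyond the scatter). Both sizes are only minimum sizes, and the true gaps cannot be read, because compound 1 and compound 2 both rest on a limit and not on a number: the limit of > 1000 nM in this assay, at which 2 of the 3 values shown sit.

The compounds shown leave open whether the gain belongs to methyl alone or extends to other groups at this position, such as ethyl, methoxy or an amine. They also leave open whether the same exchange holds when the chain on the amide is replaced by a shorter or longer chain.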